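The source may report more compounds than this note shows. Statements on the series, on what has been measured and on what is new or still open speak of the compounds shown alone.

Measured compounds in a functional assay on MDA-MB-231 cells (Homo sapiens) for antiproliferative activity, read by CCK-8 assay, with a stated time of 72 h; on this read-out lower numbers stand for stronger inhibition and higher numbers for weaker inhibition:
compound 1 `COc1ccccc1C(=O)Nc1cccc(-c2oc3cc(-c4ccc(F)cc4)ccc3c(=O)c2O)c1` gives 5110 nM
compound 2 `Cc1ccccc1C(=O)Nc1cccc(-c2oc3cc(-c4ccc(F)cc4)ccc3c(=O)c2O)c1` gives 4910 nM
compound 3 `CCc1ccc(C(=O)Nc2cccc(-c3oc4cc(-c5ccc(F)cc5)ccc4c(=O)c3O)c2)cc1` gives 9070 nM

Compound 1 stands second highest of the three numbers in this assay; its nearest neighbour is compound 2, with a 1.0-fold lower number from compound 1 to compound 2 (0.02 log units; within the scatter), and its furthest is compound 3, with a 1.8-fold higher number from compound 1 to compound 3 (0.25 log units; within the scatter). Compound 2 and compound 3 are separated by a 1.8-fold higher number from compound 2 to compound 3 (0.27 log units; within the scatter). All three amide substituents therefore sit within the scatter of one another, and nothing in these numbers separates one aryl amide from the next.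

Compound 4 `COc1ccc(C(=O)Nc2cccc(-c3oc4cc(-c5ccc(F)cc5)ccc4c(=O)c3O)c2)c(F)c1` is not yet measured. It differs from compound 1 as follows: 2-fluoro-4-methoxyphenyl in place of 2-methoxyphenyl on a carbonyl carbon. Going by the values given here, the steps that bear on this are those that exchange the aryl group on the carbonyl carbon, namely from compound 1 to compound 2 and from compound 1 to compound 3, both within the scatter. No step beyond the scatter is therefore expected in this assay from compound 1 to compound 4, and the estimated step is a 1.2-fold higher number from compound 1 to compound 4 (0.07 log units; within the scatter). Compound 4 is expected to give about 6000 nM, in the range 3000 nM to 12000 nM.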

Compound 4, half-maximal inhibitory concentration: 17600 nM
Beside the measured number, compound 4's estimate is 2.9-fold (0.47 log units) below it; measured number above the stated range.
By their numbers in this assay, from the lowest: compounds 2, 1, 3 and 4 (each within the scatter of the next, the first and the last beyond it).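

In this assay, going by these compounds alone, the aryl group on the carbonyl carbon is no longer silent: 2-fluoro-4-methoxyphenyl gives the only steps beyond the scatter at this position, both modest (a 3.4-fold higher number from compound 1 to compound 4 (0.54 log units; beyond the scatter) and a 3.6-fold higher number from compound 2 to compound 4 (0.55 log units; beyond the scatter)), while compound 3 stays unseparated from it (a 1.9-fold higher number from compound 3 to compound 4 (0.29 log units; within the scatter)). The exchange from 2-methoxyphenyl to 2-fluoro-4-methoxyphenyl brings in fluorine and also changes where the methoxy sits, and this one step does not divide the two. Nothing at hand bears on why the number rises.

On these data alone, whether the fluorine or the methoxy placement carries the step stays open, and 2-fluorophenyl and 4-methoxyphenyl amides would separate them. Also open, as far as these compounds go, is how an aryl group bearing an amine or a carboxylic acid would read at this carbonyl carbon.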